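Notes on the piperazin-1-yl to 4,4-difluoropiperidin-1-yl step

The compounds below may be only part of what the source reports. "The series", "measured", "known", "first", "only" and "open" are said of these compounds alone.

Measured so far in a physicochemical assay for solubility, read by HPLC, in phosphate buffer, at pH 6.5 (on this read-out higher numbers stand for higher solubility and lower numbers for lower solubility), for three compounds
compound 1 `COC(=O)C1=C(C)NC(c2nccs2)=NC1(C)c1ccc(F)cc1Cl` gives 18 ug/mL
compound 2 `COC(=O)C1=C(C)NC(c2nccs2)=NC1(C)c1ccc(Cl)cc1` gives 14 ug/mL
compound 3 `COC(=O)C1=C(CN2CCNCC2)NC(c2nccs2)=NC1(C)c1ccc(F)cc1` gives 250 ug/mL

Compound 3 has the highest of the three numbers in this assay and lies beyond the scatter from both compound 1 and compound 2. Compound 4 `COC(=O)C1=C(CN2CCC(F)(F)CC2)NC(c2nccs2)=NC1(C)c1ccc(F)cc1` is still unmeasured. Its difference from compound 3 is 4,4-difluoropiperidin-1-yl in place of piperazin-1-yl on a saturated chain carbon bound to a double-bonded ring carbon and the entering group has 0 hydrogen-bond donors where the leaving one has 1.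

Within the data shown here, the only measured step is a 1.3-fold lower number from compound 1 to compound 2 (0.11 log units; within the scatter) and it sits on a saturated ring carbon, so it gives no direct size for this change. Among the measured compounds shown here, no measured compound carries 4,4-difluoropiperidin-1-yl. The nearest guide is that neither compound 1 at 18 ug/mL nor compound 2 at 14 ug/mL carries piperazin-1-yl, and compound 4 lacks it too. For the measured compounds named here, a step to a lower number, beyond the scatter, is therefore expected, though this rests on only three compounds. The estimated change is a 17-fold lower number from compound 3 to compound 4 (1.22 log units; beyond the scatter) in this assay as a working figure. For compound 4 the expected value is 15 ug/mL with an estimated range from 4 ug/mL to 60 ug/mL on this read-out.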

Compound 4, solubility: < 1 ug/mL
Compound 4 ended at the assay's limit; the forecaster's own chance of this, stated with the estimate: 10%; middle value at least 15-fold (1.17 log units) away from the limit.
By their numbers in this assay, from the lowest: compounds 2 and 1 (each within the scatter of the next); then compound 3. At a limit, below all of these: compound 4.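

In this assay, the change on the saturated chain carbon bound to a double-bonded ring carbon now has a direct reading: an at least 250-fold lower number from compound 3 to compound 4 (2.39 log units; beyond the scatter), with 4,4-difluoropiperidin-1-yl in place of piperazin-1-yl and nothing else altered. Among these compounds, the only earlier step, a 1.3-fold lower number from compound 1 to compound 2 (0.11 log units; within the scatter), sits on a saturated ring carbon and gave no reading for this position, whereas this step lies beyond the scatter. The size of the step is open on one side, as the reading for compound 4 is a limit of the assay and not a number: the limit of < 1 ug/mL in this assay, at which 1 of the 4 values shown sits.

Still open, from the compounds shown here alone, is which part of the change carries the step, as the second ring nitrogen of piperazin-1-yl and the two fluorine atoms of 4,4-difluoropiperidin-1-yl change together, and a plain piperidin-1-yl or a morpholin-4-yl on the same chain carbon would help to separate them. Also open, going by these compounds, are the true size of the step and whether it holds with the 4-chlorophenyl group of compound 2 on the saturated ring carbon.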